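The source may hold more compounds than are shown below. What is called first, only, known or untested is meant among the compounds shown, and "the series" means these compounds.

Three compounds share one core, seen in compound 1 `CC1(C)N=C(N)N=C(N)N1c1ccc(SCC(=O)Nc2ccc(S(=O)(=O)F)cc2)c(Cl)c1`. In an assay on isolated protein for inhibition of Dihydrofolate reductase (Mus musculus) (a higher number here means a more potent compound, by a factor of ten per unit of this negative logarithm, a lower number a less potent compound), compound 1 gives 7.42. Compound 3 `CC1(C)N=C(N)N=C(N)N1c1ccc(OCCCCC(=O)Nc2ccc(S(=O)(=O)F)cc2)c(Cl)c1` is a related compound, and in this assay compound 3 gives 7.24, a value within the scatter of compound 1. Compound 2 `CC1(C)N=C(N)N=C(N)N1c1cccc(CCCCc2ccc(Cl)cc2Cl)c1`, whose chain ends in a 2,4-dichlorophenyl, stands highest of the three: in this assay compound 2 gives 8.03, beyond the scatter above both compound 1 and compound 3.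

Compound 4 `CC1(C)N=C(N)N=C(N)N1c1cccc(CCCCc2ccccc2)c1` has not yet been measured. It differs from compound 2 by a single change: phenyl in place of 2,4-dichlorophenyl on a saturated chain carbon, four bonds along the chain from an aromatic carbon. No measured pair among these compounds shows this same change, so the size of its effect is not established by the numbers at hand. Compound 4 is expected to lose some potency, the estimated step being a number 0.53 log units lower from compound 2 to compound 4 (beyond the scatter) in this assay, a loss beyond the scatter. In this assay compound 4 is therefore estimated at 7.5, within a range from 6.9 to 8.1.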

Compound 4, logarithm of the reciprocal of the active concentration, log(1/C): 8.35
Beside the measured number, compound 4's estimate is 0.85 log units below it; the measured number lies above the stated range.
By their numbers in this assay, from the lowest: compounds 3 and 1 (each within the scatter of the next); then compound 2; then compound 4.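

In this assay the two chlorines of the 2,4-dichlorophenyl prove unnecessary for high potency at this place, on a saturated chain carbon, four bonds along the chain from an aromatic carbon. Among these compounds, replacing that group with plain phenyl gives a number 0.32 log units higher from compound 2 to compound 4 (beyond the scatter) and so reverses the direction the earlier compounds had left unsettled, since no pair among them tested this change. Nothing measured here accounts for this modest gain.

As far as these compounds go, the change is seen in this one pair only, so whether it would hold on another chain remains unknown. Also open, from the compounds shown here alone, is how a phenyl carrying a single chlorine, a methoxy group or a carboxylic acid would compare, and whether a longer chain would keep the potency of the plain phenyl.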